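Notes on a side-chain exchange at the aryl ether

A few compounds are considered here, and "the series" means these few. Any claim that something is new, unique, unknown or untested is made for them only; others in the source may bear on it.

The series keeps one core and varies the chain attached to the oxygen on the aromatic ring. Among the compounds with values here, compound 1 `CCCCN(C)CCCOc1cc(OC)ccc1-c1cc(-c2ccccc2)no1` is the only member with a number: in a functional assay on the whole organism (blood, strain Sprague-Dawley albino) with Rattus norvegicus as the target, with stated times of 30 min and 5 h, at a dose of 100 mg/kg by the oral route (a higher number here means more inhibition at the dose given (going by the name of the read-out), a lower number less inhibition), compound 1 gives 12.6%, a weak reading. Compound 2 `CCOC(=O)CCCOc1cc(OC)ccc1-c1cc(-c2ccccc2)no1` has in this assay only the entry "not determined" (no result reported), so compound 2 stands at no number at all and offers no anchor. Compound 3 `CCN(CC)CC(O)COc1cc(OC)ccc1-c1cc(-c2ccccc2)no1` differs from compound 2 in one place: 2-(diethylamino)-1-hydroxyethyl in place of 2-(ethoxycarbonyl)ethyl on a saturated chain carbon bound to an oxygen on an aromatic ring. With compound 2 unmeasured, neither the size nor the direction of the step to compound 3 can be fixed from data; the only point of reference is the low reading of compound 1, and no step beyond the usual scatter from that level is expected. Compound 3 is therefore estimated to come out at 15%, within a range from 0% to 40%.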

Compound 3, a percentage reported as inhibition, in the whole organism at one dose (the size of the read-out at that dose, not a potency): 11.6%
Compound 3: middle estimate off by 3.4 percentage points, on the high side; the measured number falls inside the stated range.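

In this assay, replacing 2-(butyl(methyl)amino)ethyl with 2-(diethylamino)-1-hydroxyethyl on a saturated chain carbon bound to an oxygen on an aromatic ring gives a number 1 percentage points lower from compound 1 to compound 3 (within the scatter), so this position now has two amine-bearing chains whose readings cannot be told apart. The step from the ethyl ester chain of compound 2 to compound 3 cannot be read, as compound 2 has no number to start from. No measured evidence bears on this result.

Going by these compounds, compound 1 and compound 3 differ in both the amine substituents and the chain hydroxyl, so the contribution of each change stays open. Also open, on these data alone, is whether a carboxylic acid, a morpholine or a longer chain at this position would lift the reading above the level of these two compounds.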